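The source may report more compounds than this note shows. Statements on the series, on what has been measured and on what is new or still open speak of the compounds shown alone.

In a functional assay on MCF7 cells (Homo sapiens) for antiproliferative activity, read by MTT assay, with stated times of 24 h and 72 h (on this read-out higher numbers stand for weaker inhibition and lower numbers for stronger inhibition), compound 1 `COc1cc([C@@H]2[C@H](Oc3ccccc3)C(=O)N2c2cc(OC)c(OC)c(OC)c2)cc(OC)c1OC` gives 29000 nM and compound 2 `COc1ccc([C@@H]2[C@H](Oc3ccccc3)C(=O)N2c2cc(OC)c(OC)c(OC)c2)cc1` gives 35000 nM, so these two sit together at the weak end of the three numbers. Compound 3 `COc1ccc([C@@H]2[C@@H](Oc3ccccc3)C(=O)N2c2cc(OC)c(OC)c(OC)c2)cc1` gives 6900 nM, clearly stronger than compound 2. Among the measured compounds shown here, the series so far holds two single changes. Replacing 3,4,5-trimethoxyphenyl with 4-methoxyphenyl gives a 1.2-fold higher number from compound 1 to compound 2 (0.08 log units; within the scatter). For the measured compounds named here, changing one stereocentre gives a 5.1-fold lower number from compound 2 to compound 3 (0.71 log units; beyond the scatter), the one modest step on hand, and the only thing to point to for it is the fact that compounds 2 and 3 differ only in the configuration as drawn.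

Compound 4 `CCOC(=O)/C=C/c1ccc([C@@H]2[C@H](Oc3ccccc3)C(=O)N2c2cc(OC)c(OC)c(OC)c2)cc1` carries a 2-(ethoxycarbonyl)ethenyl in place of the methoxy on an aromatic carbon, para to a large group: 2-(ethoxycarbonyl)ethenyl in place of methoxy on an aromatic carbon. The stereo step does not bear on this change, since compound 4 has the drawn configuration of compound 2. The aryl change is the closer precedent, and the step to compound 2 at 35000 nM stayed within the scatter. The new group is much larger than anything tried at this place, so that precedent is weak, and the range is kept wide. No step beyond the scatter is expected in this assay, and the estimated change is a 1.3-fold lower number from compound 2 to compound 4 (0.10 log units; within the scatter). The expected value for compound 4 is 28000 nM, with an estimated range of 8000 nM to 90000 nM.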

Compound 4, half-maximal inhibitory concentration: 87000 nM
For compound 4 the middle estimate is 3.1-fold (0.49 log units) below the measured one; measured number inside the range.
By their numbers in this assay, from the lowest: compound 3; then compounds 1 and 2 (each within the scatter of the next); then compound 4.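

In this assay, the aromatic carbon para to a large group now shows a step beyond the scatter: 2-(ethoxycarbonyl)ethenyl in place of methoxy gives a 2.5-fold higher number from compound 2 to compound 4 (0.40 log units; beyond the scatter), towards weaker inhibition. The earlier aryl change, with a 1.2-fold higher number from compound 1 to compound 2 (0.08 log units; within the scatter), stayed within the scatter, so this aryl ring can no longer be read as a part of the series where changes leave the number unmoved, although the two changes differ in kind and in place. Among the compounds shown here, the only evidence on hand concerns configuration and does not bear on this substituent change, so no cause can be given for the step.

The compounds shown leave open whether the step belongs to the ester, to the double bond or to the length of the group; a carboxylic acid in place of the ethyl ester, or a saturated ethyl propanoate chain, would separate these. Also open, as far as these compounds go, is whether the configuration drawn in compound 3, which goes with a 5.1-fold lower number from compound 2 to compound 3 (0.71 log units; beyond the scatter) for the methoxy compounds, would lower the number in the same way with 2-(ethoxycarbonyl)ethenyl in place.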